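The compounds below may be only part of what the source reports. "The series", "measured", "known", "first", "only" and "open" are said of these compounds alone.

Within the data shown here, in a physicochemical assay for solubility, read by spectrophotometry, using the shake flask method, with a stated time of 2 days, at pH 6.5 (on this read-out lower numbers stand for lower solubility and higher numbers for higher solubility), three compounds have numbers so far. Compound 1 (`Oc1ccc(-n2cc(-c3ccc4ccccc4n3)nn2)cc1`) gives 2.2 ug/mL and is the lowest of the three. Compound 2 (`O=C(O)c1cccc(Oc2cccc3nc(-c4cn(-c5ccc(O)c(F)c5)nn4)ccc23)c1`) gives 47.2 ug/mL and compound 3 (`O=C(O)COc1ccc2nc(-c3cn(-c4ccccc4)nn3)ccc2c1`) gives 1050 ug/mL on the same scale, both beyond the scatter from compound 1.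

Compound 4 (`COCCOCCOc1ccc2nc(-c3cn(-c4ccc(O)cc4)nn3)ccc2c1`) has not been measured yet. It differs from compound 1 in one place (2-(2-methoxyethoxy)ethoxy in place of hydrogen on an aromatic carbon): a 2-(2-methoxyethoxy)ethoxy stands in place of hydrogen on an aromatic carbon of the shared core. Among the measured compounds shown here, no two measured compounds differ in one place only, and this step in this assay therefore has no direct comparison. Compound 1 at 2.2 ug/mL stands under compound 2 and compound 3, each of which carries a further group on the core, though each also differs in other ways. On that loose ground a rise beyond the scatter is expected, and the estimated step is a 6.4-fold higher number from compound 1 to compound 4 (0.80 log units; beyond the scatter) in the upward direction. For compound 4 the estimate is 14 ug/mL with an expected range from 4 ug/mL to 50 ug/mL on this measure.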

Compound 4, solubility: 2.4 ug/mL
Estimate against measurement, compound 4: 5.8-fold (0.77 log units) above; measured number outside the range, below it.
By their numbers in this assay, from the lowest: compounds 1 and 4 (each within the scatter of the next); then compound 2; then compound 3.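

In this assay, among these compounds, placing 2-(2-methoxyethoxy)ethoxy in place of hydrogen gives a 1.1-fold higher number from compound 1 to compound 4 (0.04 log units; within the scatter), the first direct reading of a single change on this core. At this aromatic carbon of the fused system, therefore, a chain of 8 heavy atoms with 3 hydrogen-bond acceptors, no hydrogen-bond donors and no net charge leaves the read-out of compound 4 within the scatter of compound 1. No measurement at hand explains this result.

The compounds shown leave open whether an amine at the same aromatic carbon would give a step beyond the scatter. They also leave open whether a longer chain there, or the same 2-(2-methoxyethoxy)ethoxy on another carbon of the core, would give such a step.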